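The source may report more compounds than this note shows. Statements on the series, on what has been measured and on what is new or still open speak of the compounds shown alone.

In an assay for inhibition of Indoleamine 2,3-dioxygenase 1 (Homo sapiens), with stated times of 10 min and 60 min (a lower number here means a stronger inhibitor, a higher number a weaker inhibitor), compound 1 `FC(F)(F)c1cc(NC[C@H]2CCCN2)c2cn[nH]c2c1` gives 9580 nM. Compound 2 `CNC(=O)c1cccc(CNc2cc(C(F)(F)F)cc3[nH]ncc23)c1` reaches only the limit of this assay, reported as > 100000 nM (the limit of > 100000 nM in this assay, at which 1 of the 2 values shown sits), so no number is known for it. Compound 3 `Nc1cccc(CNc2cc(C(F)(F)F)cc3[nH]ncc23)c1` carries amino in place of methylcarbamoyl on an aromatic carbon, that is, amino in place of methylcarbamoyl on an aromatic carbon. Within the data shown here, no measured pair shows what this exchange does, so the expected step from compound 2 to compound 3 in this assay, an at least 1.2-fold lower number from compound 2 to compound 3 (0.09 log units; that floor lies within the scatter), is small and uncertain in direction. Compound 3 is expected near 80000 nM, somewhere between 15000 nM and 300000 nM in this assay.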

Compound 3, half-maximal inhibitory concentration: > 100000 nM
Compound 3: only a limit was reported (the forecaster's own chance of this, stated with the estimate: 55%); middle value at least 1.2-fold (0.09 log units) from the limit.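

In this assay compound 3 gives > 100000 nM, which is a limit and not a number. The step between the two limit compounds cannot be read, but amino, like methylcarbamoyl, leaves the compound at the limit: the limit of > 100000 nM in this assay, at which 2 of the 3 values shown sit.

With 3-aminophenyl in place of pyrrolidin-2-yl on the saturated chain carbon, the result is an at least 10-fold higher number from compound 1 to compound 3 (1.01 log units; beyond the scatter), so this aromatic group with amino on it gives no number where the pyrrolidin-2-yl compound does.

On these data alone, whether a hydroxyl or a carboxylic acid on this aromatic carbon would give a measurable number remains open. As far as these compounds go, how compound 2 and compound 3 truly rank also remains open.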